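Chloro position in the cinnamamide tail of compound 1

The source may report more compounds than this note shows. Statements on the series, on what has been measured and on what is new or still open speak of the compounds shown alone.

All numbers below come from a functional assay on HEK293 cells for activation of melanin-concentrating hormone receptor 1 (Homo sapiens), read by inositol phosphate accumulation; a lower number here means that less compound is needed, a higher number that more compound is needed for the effect.

- compound 1, `CCCc1cc(N)c2cc(NC(=O)/C=C/c3ccc(Cl)cc3)ccc2n1`: 96 nM
- compound 2, `CC(C)c1cc(N)c2cc(NC(=O)/C=C/c3ccc(C(F)(F)F)cc3)ccc2n1`: 160 nM
- compound 3, `Cc1cc(N)c2cc(NC(=O)/C=C/c3ccc(C(F)(F)F)cc3)ccc2n1`: 140 nM

Compound 1 gives the lowest of the three numbers, but its gap to compound 3 and to compound 2 both lie within the scatter, so the three cannot be ordered. Within the data shown here, the one measured step on the shared core, a 1.1-fold lower number from compound 2 to compound 3 (0.06 log units; within the scatter), concerns the substituent on the aromatic carbon at the other end of the molecule and lies within the scatter as well.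

Compound 4, `CCCc1cc(N)c2cc(NC(=O)/C=C/c3ccccc3Cl)ccc2n1`, has yet to be measured. Relative to compound 1 the change is 2-chlorophenyl in place of 4-chlorophenyl on a double-bonded chain carbon bound to a double-bonded chain carbon.

Among the measured compounds shown here, no measured pair touches the chlorophenyl end of the molecule, so nothing here bears directly on this change; the step between compound 2 and compound 3 is at a different place and was flat. For the measured compounds named here, with the same atoms rearranged and no precedent, the estimate for compound 4 in this assay is set close to compound 1, as 150 nM, within 50 nM to 450 nM. The estimated step is therefore a 1.6-fold higher number from compound 1 to compound 4 (0.19 log units; within the scatter), expected to stay within the scatter, with the wide range reflecting the missing precedent.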

Compound 4, half-maximal effective concentration: 500 nM
For compound 4 the middle estimate is 3.3-fold (0.52 log units) below the measured one; the whole stated range lies below it.
By their numbers in this assay, from the lowest: compounds 1, 3 and 2 (each within the scatter of the next); then compound 4.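

In this assay, 2-chlorophenyl in place of 4-chlorophenyl on a double-bonded chain carbon bound to a double-bonded chain carbon gives a 5.2-fold higher number from compound 1 to compound 4 (0.72 log units; beyond the scatter). Among these compounds, this is the first measured change at the chlorophenyl end of the molecule, and it shows that the number here responds to where the chlorine stands, even though the heavy-atom count of the group is the same and the group's hydrogen-bond donor and acceptor counts stay at zero; the only earlier step, a 1.1-fold lower number from compound 2 to compound 3 (0.06 log units; within the scatter), was at the other end of the molecule and gave no such signal. Among the compounds shown here, nothing measured so far accounts for this step.

Going by these compounds, whether the higher number is tied to chlorine itself stays open, and a bromine, a methyl or a methoxy group in the place the chlorine holds in the 2-chlorophenyl of compound 4 would address that. Also open, on these data alone, is whether the same step appears when methyl or isopropyl stands in place of the propyl chain of compound 4 on the aromatic carbon.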